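Adding a second chloro to compound 2

The source may report more compounds than this note shows. Statements on the series, on what has been measured and on what is new or still open speak of the compounds shown alone.

Measured so far in a functional assay on FM3A cells (Mus musculus) for antiproliferative activity, with a stated time of 48 h; a lower number here means a stronger inhibitor, a higher number a weaker inhibitor:
- compound 1 `C=C(Br)C(=O)Nc1ccc(/C=C/C(=O)c2ccccc2)cc1`: 3900 nM
- compound 2 `C=C(Br)C(=O)Nc1ccc(/C=C/C(=O)c2ccc(Cl)cc2)cc1`: 1300 nM

Of these two, compound 2 has the lower number, so it is the stronger inhibitor. Its neighbour, compound 1, has a higher number, and the gap lies beyond the usual scatter of repeat measurements.

The next compound is compound 3 `C=C(Br)C(=O)Nc1ccc(/C=C/C(=O)c2ccc(Cl)c(Cl)c2)cc1`. It differs from compound 2 in one place: chloro in place of hydrogen on an aromatic carbon. This puts chloro in place of hydrogen on an aromatic carbon, turning 4-chlorophenyl into 3,4-dichlorophenyl.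

For the measured compounds named here, only one measured step bears on this change: a 3.0-fold lower number from compound 1 to compound 2 (0.48 log units; beyond the scatter). That step is the same kind of swap, made at a different ring carbon, and it is modest. A single step is thin evidence, and nothing shows that a second chloro repeats the size of the first. A step in the same direction is still the best guess, probably smaller and possibly within the scatter.

The expected change is a 1.6-fold lower number from compound 2 to compound 3 (0.21 log units; within the scatter). For compound 3 the estimated value in this assay is 800 nM, with an expected range of 300 nM to 2000 nM.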

Compound 3, half-maximal inhibitory concentration: 3200 nM
The estimate for compound 3 lay 4.0-fold (0.60 log units) below the measured number; the whole stated range lies below it.
By their numbers in this assay, from the lowest: compound 2; then compounds 3 and 1 (each within the scatter of the next).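

In this assay, the same swap of hydrogen for chloro does not carry over from one ring carbon to another: the first chloro gave a 3.0-fold lower number from compound 1 to compound 2 (0.48 log units; beyond the scatter), while the second, ortho to a chloro group and meta to a large group, gives a 2.5-fold higher number from compound 2 to compound 3 (0.39 log units; beyond the scatter). So the benefit of a chloro depends on where it sits on this ring, and adding more chloro does not simply add more of the same effect. Set against the unsubstituted ring, the two chloro groups together give a 1.2-fold lower number from compound 1 to compound 3 (0.09 log units; within the scatter), which means that 3,4-dichlorophenyl cannot be told apart from phenyl here, and only 4-chlorophenyl stands out from both. Nothing in the available data explains why the second chloro undoes the step made by the first.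

On these data alone, it stays open whether the higher number of compound 3 needs both chloro groups together or would come with any chloro on this ring carbon, even without the first one. The compounds shown also leave open how a different group on this carbon, such as a methoxy group, an amine or a carboxylic acid, would compare with the chloro.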